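Compound 3: what follows from compound 2

The compounds below may be only part of what the source reports. "The series", "measured", "known", "first", "only" and "open" are said of these compounds alone.

Compound 1 `c1ccc2c(c1)CN[C@@H](CN(CCCN1CCNCC1)[C@H]1CCCc3cccnc31)C2`: 100%
Compound 2 `c1ccc2c(c1)CN[C@@H](CN(CC[C@H]1CCCNC1)[C@H]1CCCc3cccnc31)C2`: 55%

In an ADME assay on microsomes from liver (Rattus norvegicus) for metabolic stability, read by LC-MS, with a stated time of 10 min, tested at 0.5 uM (on this read-out higher numbers stand for a more stable compound and lower numbers for a less stable compound), compound 2 stands lowest of the two at 55%, while compound 1 gives 100%. Compound 3 `c1ccc2c(c1)CN[C@@H](CN(CCCCN1CCNCC1)[C@H]1CCCc3cccnc31)C2` differs from compound 2 by 2-(piperazin-1-yl)ethyl in place of piperidin-3-yl on a saturated chain carbon, two bonds along the chain from an amine nitrogen, with 2-(piperazin-1-yl)ethyl in place of piperidin-3-yl on a saturated chain carbon. Going by the values given here, one measured step bears on this: a number 45 percentage points lower from compound 1 to compound 2 (beyond the scatter), a large drop on leaving (piperazin-1-yl)methyl for piperidin-3-yl. Compound 3 returns to a piperazin-1-yl group, but 2-(piperazin-1-yl)ethyl itself is unmeasured, so only part of that drop is surely recovered. The expected step is a number 30 percentage points higher from compound 2 to compound 3 (beyond the scatter), a rise beyond the scatter. For compound 3 the estimated value is 85%, within an expected range of 62% to 100%.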

Compound 3, percent of the compound remaining: 15%
For compound 3 the middle estimate is 70 percentage points above the measured one; measured number outside the range, below it.
By their numbers in this assay, from the lowest: compound 3; then compound 2; then compound 1.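

In this assay, 2-(piperazin-1-yl)ethyl in place of piperidin-3-yl gives a number 40 percentage points lower from compound 2 to compound 3 (beyond the scatter), so a terminal piperazin-1-yl group does not by itself restore the read-out. With that group kept, (piperazin-1-yl)methyl in place of piperazin-1-yl brings a number 85 percentage points lower from compound 1 to compound 3 (beyond the scatter), which shows that chain length matters greatly here. Nothing available explains this loss. On these data alone, whether a morpholin-4-yl group on the same chain would follow the piperazin-1-yl compounds remains open, as does the result for a still longer chain.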